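Notes on the aryl substituent change from compound 3 to compound 4

The source may report more compounds than this note shows. Statements on the series, on what has been measured and on what is new or still open speak of the compounds shown alone.

Compound 3 `Cn1nc2c(=O)n(CC3(O)CCN(Cc4ccc(-c5cncs5)cc4Cl)CC3)cnc2c1-c1ccc(CN)cc1` is the reference point for this step. In an assay on isolated protein for inhibition of ubiquitin carboxyl-terminal hydrolase 7 (Homo sapiens), with stated times of 30 min and 2 h (a lower number here means a stronger inhibitor, a higher number a weaker inhibitor), compound 3 gives 117 nM. Compound 1 `Cn1nc2c(=O)n(CC3(O)CCN(Cc4ccc(-c5ccco5)cc4Cl)CC3)cnc2c1-c1ccc(C(F)(F)F)cc1` gives 530 nM and compound 2 `CC(C)NCc1ccc(-c2c3ncn(CC4(O)CCN(Cc5ccc(-c6ccco6)cc5Cl)CC4)c(=O)c3nn2C)cc1` gives 29.1 nM. Compound 3 thus stands second of the three numbers, nearer to compound 2 and further from compound 1, both gaps beyond the scatter.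

For the measured compounds named here, the only single-point step measured so far is an 18-fold lower number from compound 1 to compound 2 (1.26 log units; beyond the scatter). That step concerns the other aromatic ring of the shared core and does not touch the ring changed here.

Compound 4 `Cn1nc2c(=O)n(CC3(O)CCN(Cc4ccc(C5CCCO5)cc4Cl)CC3)cnc2c1-c1ccc(CN)cc1` differs from compound 3 by oxolan-2-yl in place of 1,3-thiazol-5-yl on an aromatic carbon. Going by the values given here, compound 1 and compound 3 differ in two places, so their values give no clean reading of the ring at this position; the two numbers show only that compound 1 carries the higher one. Among the compounds with values here, no measured step therefore bears directly on this change, and the expectation rests on the change itself. A small step is expected, more likely toward a higher number yet possibly within the scatter, so that a 1.5-fold higher number from compound 3 to compound 4 (0.19 log units; within the scatter) is the estimated step. For compound 4 the estimate is 180 nM, with a range from 60 nM to 600 nM.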

Compound 4, half-maximal inhibitory concentration: 3820 nM
Compound 4: the middle estimate sits 21-fold (1.33 log units) below what was measured; the measured number lies above the stated range.
By their numbers in this assay, from the lowest: compound 2; then compound 3; then compound 1; then compound 4.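

In this assay, replacing 1,3-thiazol-5-yl with oxolan-2-yl on the aromatic carbon para to a large group gives a 33-fold higher number from compound 3 to compound 4 (1.51 log units; beyond the scatter), the first single-place step read at this position, and it shows that the number here depends strongly on the ring carried there. Both groups have the same count of heavy atoms and no net charge, so a large step arises with no change in either: what differs is one five-membered aromatic ring with 2 hetero atoms against one five-membered non-aromatic ring with 1 hetero atom, with nitrogen and sulfur leaving and oxygen entering. No measurement at hand accounts for the size of this step.

With a single clean pair at this position, the compounds shown do not separate the loss of the aromatic ring from the exchange of hetero atoms. A thiolan-2-yl group, which would keep the sulfur in a non-aromatic ring, and a plain phenyl ring, which would keep the aromatic ring without hetero atoms, would each bear on that open question.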